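Swapping an indole for a dialkoxyphenyl on a sulfone scaffold

The source may hold more compounds than are shown below. What is called first, only, known or untested is meant among the compounds shown, and "the series" means these compounds.

Of the compounds shown here, three have been measured in a functional assay on DU-145 cells (Homo sapiens) for inhibition, read by trypan blue exclusion, with a stated time of 96 h; a lower number here means a stronger inhibitor of growth, a higher number a weaker inhibitor of growth. Compound 1 `O=C(/C(=C\c1ccc(Cl)cc1)Sc1ccc(Br)cc1)c1ccc(Br)cc1` gives 1000 nM. Compound 2 `Cc1ccc(CS(=O)(=O)/C(=C/c2c[nH]c3ccccc23)C(=O)c2ccc(Cl)cc2)cc1` gives 25000 nM, and compound 3 `O=C(/C(=C\c1ccc(OC(F)(F)F)cc1)S(=O)(=O)c1ccc(Br)cc1)c1ccc(Br)cc1` gives 25000 nM. Compound 2 therefore stands level with compound 3 at the digits shown, together the highest numbers of the three, while compound 1 shows a lower number, a gap beyond the usual scatter.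

Compound 4 `CCOc1ccc(/C=C(\C(=O)c2ccc(Cl)cc2)S(=O)(=O)Cc2ccc(C)cc2)cc1OC` is not yet measured. It differs from compound 2 in one place: 4-ethoxy-3-methoxyphenyl in place of 1H-indol-3-yl on a double-bonded chain carbon bound to a double-bonded chain carbon. Among the compounds with values here, no measured pair shows this change, so its effect is open. Compound 4 keeps the rest of compound 2, so only a step within the usual scatter is expected, a 1.3-fold lower number from compound 2 to compound 4 (0.10 log units; within the scatter). Compound 4 is estimated at 20000 nM, within 5000 nM to 80000 nM.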

Compound 4, concentration for 50% growth inhibition: 10000 nM
Compound 4: the middle estimate sits 2.0-fold (0.30 log units) above what was measured; the measured number falls inside the stated range.
By their numbers in this assay, from the lowest: compound 1; then compound 4; then compounds 2 and 3 (each within the scatter of the next).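

This position does not depend on the indole for growth inhibition. In this assay, 4-ethoxy-3-methoxyphenyl in place of 1H-indol-3-yl gives a 2.5-fold lower number from compound 2 to compound 4 (0.40 log units; beyond the scatter), a modest gain even though the hydrogen-bond donor of the indole is gone and hydrogen-bond acceptors enter. No measurement here accounts for this step.

Going by these compounds, both alkoxy groups enter together, so the share of the ethoxy and that of the methoxy stay unknown. On these data alone, how an amine or a carboxylic acid on that phenyl ring would behave also remains open.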